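A few compounds are considered here, and "the series" means these few. Any claim that something is new, unique, unknown or untested is made for them only; others in the source may bear on it.

In an assay on HEK293 cells for inhibition of Leucine-rich repeat serine/threonine-protein kinase 2 variant G2019S (Homo sapiens), with a stated time of 48 h (on this read-out higher numbers stand for weaker inhibition and lower numbers for stronger inhibition), two compounds have been measured. Compound 1 `Cc1c(Nc2nc(N)c3c(C#N)c(N4CCC[C@H]4C)n(C)c3n2)cnn1C` gives 260 nM in this assay. Within the data shown here, compound 2 `C[C@@H]1CCCN1c1c(C#N)c2c(N)nc(Nc3cn(C)nc3Cl)nc2n1C` gives 54 nM in this assay, which is the lower of the two numbers, the only measured step being a 4.8-fold lower number from compound 1 to compound 2 (0.68 log units; beyond the scatter).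

Compound 3 `C[C@@H]1CCCN1c1c(C#N)c2c(N)nc(Nc3cn(C)nc3C(F)(F)F)nc2n1C` has not been measured. It differs from compound 2 in one place: trifluoromethyl in place of chloro on an aromatic carbon. Read one bond further out, the 3-chloro-1-methyl-1H-pyrazol-4-yl group of compound 2 becomes 1-methyl-3-(trifluoromethyl)-1H-pyrazol-4-yl in compound 3.

Among the measured compounds shown here, only one measured step, a 4.8-fold lower number from compound 1 to compound 2 (0.68 log units; beyond the scatter), touches this part of the molecule, and it exchanged a methyl for a chloro, not a chloro for a trifluoromethyl, so it bears on the present change only loosely. For the measured compounds named here, that step was modest, and there is no measured example of trifluoromethyl at all, so the expected step of a 1.5-fold higher number from compound 2 to compound 3 (0.17 log units; within the scatter) is set small, with no clear direction beyond the scatter. On that basis compound 3 is estimated at 80 nM in this assay, with a likely range from 25 nM to 260 nM.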

Compound 3, half-maximal inhibitory concentration: 460 nM
For compound 3 the middle estimate is 5.8-fold (0.76 log units) below the measured one; measured number above the stated range.
By their numbers in this assay, from the lowest: compound 2; then compounds 1 and 3 (each within the scatter of the next).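

In this assay, replacing the chloro with a trifluoromethyl on this aromatic carbon, next to the ring nitrogen, is far from a neutral exchange: the result is an 8.5-fold higher number from compound 2 to compound 3 (0.93 log units; beyond the scatter) and so the two groups cannot be treated as interchangeable here. The 1-methyl-3-(trifluoromethyl)-1H-pyrazol-4-yl group also fails to keep the advantage of the 3-chloro-1-methyl-1H-pyrazol-4-yl group over the 1,5-dimethyl-1H-pyrazol-4-yl group, since the comparison with the dimethyl compound reads a 1.8-fold higher number from compound 1 to compound 3 (0.25 log units; within the scatter) and compound 2 alone stands apart from the other two beyond the scatter. Nothing available explains why the chloro and the trifluoromethyl differ so much at this position.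

The compounds shown leave open how a fluoro, a bromo, a methyl or a methoxy on this same carbon would compare with the chloro, and so whether the chloro is a narrow optimum or one of several good groups. They also leave open whether the gap between chloro and trifluoromethyl would persist with other groups elsewhere on the shared core.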